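Trimming the oxane ring of compound 2

This account rests on a few compounds, and the source may have more. Where it says the series, first, only, none or still open, it means among the compounds named here.

Compound 1 `COc1ccccc1-n1nc([C@H]2C[C@@H](C)O[C@@H](C)C2)cc1-c1ccc(Cl)cc1` gives 3 nM in an assay on HEK293 cells for inhibition of Voltage-dependent N-type calcium channel subunit alpha-1B (Homo sapiens), read by fluorescence and calcium flux, with a stated time of 5 min; on this read-out lower numbers stand for stronger inhibition and higher numbers for weaker inhibition.
Compound 2 `COc1ccccc1-n1nc(C2CC(C)(C)OC(C)(C)C2)cc1-c1ccc(Cl)cc1` gives 1 nM in this assay.
Compound 3 `CCOc1ccc(-c2cc(C3CC(C)(C)OC(C)(C)C3)nn2-c2ccccc2OC)cc1` gives 2 nM in this assay.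

Compound 2 shows the lowest of the three numbers. Compound 3 stands nearest, with a 2.0-fold higher number from compound 2 to compound 3 (0.30 log units; within the scatter) lying within the scatter, and compound 1 stands furthest, with a 3.0-fold lower number from compound 1 to compound 2 (0.48 log units; beyond the scatter) lying beyond it. Compound 4 `COc1ccccc1-n1nc(C2CCOC(C)(C)C2)cc1-c1ccc(Cl)cc1` differs from compound 2 in one place: 2,2-dimethyloxan-4-yl in place of 2,2,6,6-tetramethyloxan-4-yl on an aromatic carbon. Among the compounds with values here, only one measured step bears on this change, the one on the same ring, a 3.0-fold lower number from compound 1 to compound 2 (0.48 log units; beyond the scatter), which was modest. The step from compound 2 to compound 3 concerns the other aryl group and says nothing about the oxane ring. Compound 4 carries a ring whose methyl pattern lies between that of compound 1 and that of compound 2, so a small rise in the number is expected, of a size near the scatter rather than beyond it. Compound 4 is therefore expected to give about 2 nM in this assay, with a range from 0.8 nM to 6 nM. The expected step is a 2.0-fold higher number from compound 2 to compound 4 (0.30 log units; within the scatter).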

Compound 4, half-maximal inhibitory concentration: 2 nM
Beside the measured number, compound 4's estimate shows no gap at the digits printed; the range from low to high includes it.
By their numbers in this assay, from the lowest: compounds 2, 3, 4 and 1 (each within the scatter of the next, the first and the last beyond it).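

On the oxane ring, the 2,2-dimethyloxan-4-yl group in place of 2,2,6,6-tetramethyloxan-4-yl gives a 2.0-fold higher number from compound 2 to compound 4 (0.30 log units; within the scatter), so in this assay the methyl groups that compound 4 lacks can go without a step beyond the scatter. The same ring also stands close to the 2,6-dimethyloxan-4-yl group, with a 1.5-fold lower number from compound 1 to compound 4 (0.18 log units; within the scatter), so compound 4 sits within the scatter of both neighbours, although the step between those two lies beyond it. Nothing available here accounts for these readings.

The compounds shown leave open how an unsubstituted oxan-4-yl ring or a piperidin-4-yl amine would read on this aromatic carbon. They also leave open whether the 2,2-dimethyloxan-4-yl group would read alike beside the ethoxy group of compound 3.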